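Adding a Second Trifluoromethyl Group to Compound 3

The compounds below may be only part of what the source reports. "The series", "measured", "known", "first", "only" and "open" are said of these compounds alone.

The measured compounds:
Compound 1, `CNc1nc(C)c(C(=O)N/N=C/c2cccc(C(F)(F)F)c2)s1`, gives > 100 ug/mL.
Compound 2, `CNc1nc(C)c(C(=O)N/N=C/c2cc(C(F)(F)F)cc(C(F)(F)F)c2)s1`, gives > 100 ug/mL.
Compound 3, `CN(C(=O)NC(=O)c1ccc(C(F)(F)F)cc1)c1nc(C(F)(F)F)c(C(=O)N/N=C/c2cccc(C(F)(F)F)c2)s1`, gives 7.95 ug/mL.

In a functional assay on HepG2 cells (Homo sapiens) for inhibition, read by MTT assay, with a stated time of 72 h (a lower number here means a stronger inhibitor, a higher number a weaker inhibitor), compound 1 gives > 100 ug/mL, which is a limit of the assay rather than a number. Compound 2 gives > 100 ug/mL, again a limit and not a number. The change from compound 1 to compound 2 is trifluoromethyl in place of hydrogen on an aromatic carbon, and the step it made is a step that the two limits leave unreadable from compound 1 to compound 2. Both values sit at the limit of > 100 ug/mL in this assay, at which 2 of the 3 values shown sit, so this pair tells nothing about the size of the change.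

Compound 3 is built on a different core; the difference between the core of compound 3 and the core of compound 1 is not broken down here. In this assay, within the data shown here, compound 3 gives 7.95 ug/mL, the only real number among the three.

Compound 4, `CN(C(=O)NC(=O)c1ccc(C(F)(F)F)cc1)c1nc(C(F)(F)F)c(C(=O)N/N=C/c2cc(C(F)(F)F)cc(C(F)(F)F)c2)s1`, has not yet been measured. It differs from compound 3 by trifluoromethyl in place of hydrogen on an aromatic carbon, the same change that turns compound 1 into compound 2. Since the step from compound 1 to compound 2 is hidden by the two limits, there is no measured guide to what this change does. The plainest expectation is that compound 4 stays close to compound 3, with the step from compound 3 to compound 4 expected to be a 1.3-fold higher number from compound 3 to compound 4 (0.10 log units; within the scatter). Compound 4 is therefore estimated at 10 ug/mL in this assay, with a likely range from 4 ug/mL to 30 ug/mL.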

Compound 4, half-maximal inhibitory concentration: 8.35 ug/mL
The estimate for compound 4 lay 1.2-fold (0.08 log units) above the measured number, within the range that was stated.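

In this assay, the second trifluoromethyl group on the core of compound 3 gives a 1.1-fold higher number from compound 3 to compound 4 (0.02 log units; within the scatter), so on this core the added group leaves the read-out indistinguishable from that of the parent compound. The matching pair on the other core gives no number to set against this, as compound 1 and compound 2 both stand at a limit of the assay rather than at a real value, which leaves their step unreadable: the limit of > 100 ug/mL in this assay, at which 2 of the 4 values shown sit. The change has therefore been read on one core only, so this series cannot show whether it carries over from one core to the other, and a single pair is no basis for a general rule even on the core of compound 3.

The compounds shown leave open whether any other group at this place on the six-membered aromatic ring would matter, such as an amine, a carboxylic acid or a longer chain in place of the second trifluoromethyl group. They also leave open which part of the core of compound 3 separates it from the core of compound 1, since those two cores differ in more than one place.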